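Urea in place of neopentyl on a stable scaffold

A few compounds are considered here, and "the series" means these few. Any claim that something is new, unique, unknown or untested is made for them only; others in the source may bear on it.

Of the compounds shown here, three built on one shared core have been tested in an ADME assay on microsomes from liver (Rattus norvegicus) for metabolic stability, with a stated time of 10 min; on this read-out lower numbers stand for a less stable compound and higher numbers for a more stable compound. Compound 1 `CC(C)S(=O)(=O)NC(=O)c1ccc(Nc2nc(NC3(c4ccc(Cl)cc4)CC3)nc(OCC(F)(F)F)n2)cc1` gives 96%. Compound 2 `CC(C)(C)NC(=O)NCCS(=O)(=O)NC(=O)c1ccc(Nc2nc(NC3(c4ccc(Cl)cc4)CC3)nc(OCC(F)(F)F)n2)cc1` gives 93%. Compound 3 `CC(C)(C)CNCCS(=O)(=O)NC(=O)c1ccc(Nc2nc(NC3(c4ccc(Cl)cc4)CC3)nc(OCC(F)(F)F)n2)cc1` gives 90%. All three numbers sit close together: the steps of a number 3 percentage points lower from compound 1 to compound 2 (within the scatter), a number 6 percentage points lower from compound 1 to compound 3 (within the scatter) and a number 3 percentage points lower from compound 2 to compound 3 (within the scatter) all lie within the usual scatter, so compound 3 cannot be told apart from the other two on this read-out.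

Compound 4 `CNC(=O)NCCS(=O)(=O)NC(=O)c1ccc(Nc2nc(NC3(c4ccc(Cl)cc4)CC3)nc(OCC(F)(F)F)n2)cc1` differs from compound 3 in one place: methylcarbamoyl in place of neopentyl on an amine nitrogen. Among the measured compounds shown here, the closest measured step is the one from compound 2 to compound 3, where a carbamoyl group on that same amine nitrogen was swapped for neopentyl, and it gave a number 3 percentage points lower from compound 2 to compound 3 (within the scatter). Going back toward a carbamoyl group is therefore expected to move the number by a number 3 percentage points higher from compound 3 to compound 4 (within the scatter), that is, nothing beyond the scatter. Compound 4 is expected to give 93%, most likely between 85% and 99%.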

Compound 4, percent of the compound remaining: 100%
For compound 4 the middle estimate is 7 percentage points below the measured one, outside the stated range (above it).
By their numbers in this assay, from the lowest: compounds 3, 2, 1 and 4 (each within the scatter of the next).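

In this assay, the end of the chain on the sulfonyl sulfur takes a methylcarbamoyl group with no step beyond the scatter, whether it is methylcarbamoyl in place of neopentyl on the amine nitrogen (a number 10 percentage points higher from compound 3 to compound 4 (within the scatter)), methyl in place of tert-butyl on the amide-type nitrogen (a number 7 percentage points higher from compound 2 to compound 4 (within the scatter)), or the whole 2-((methylcarbamoyl)amino)ethyl in place of isopropyl (a number 4 percentage points higher from compound 1 to compound 4 (within the scatter)). Earlier compounds showed this tolerance for the bulkier tert-butyl urea and the neopentyl amine; compound 4 extends it to a urea ending in a methyl. No measurement here bears on why the number stays this high.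

From the compounds shown here alone, how a free amine, a carboxylic acid or a longer chain would behave at this position remains open. So does whether any real difference among these four compounds exists, since this read-out does not separate them.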